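This account rests on a few compounds, and the source may have more. Where it says the series, first, only, none or still open, it means among the compounds named here.

Compound 1 `C(=C1\CCCC\C1=N/Nc1nc(-c2ccccc2)cs1)\c1ccccc1` has been run in an ADME assay on Vero cells (Chlorocebus sabaeus) for cytotoxicity, read by MTT assay, with a stated time of 48 h (on this read-out higher numbers stand for weaker inhibition and lower numbers for stronger inhibition), and there compound 1 gives > 100000 nM, which is a limit of the assay and not a number. Compound 2 `COc1ccc(-c2csc(N/N=C(\C)CCO)n2)cc1` gives in this assay > 100000 nM, also a limit. Compound 3 `C(=N/Nc1nc(-c2ccccc2)cs1)\C1CCCCC1` gives in this assay > 100000 nM, again a limit. Going by the values given here, no two measured compounds differ in a single place, so no measured step can be followed; all three values sit at the limit of > 100000 nM in this assay, at which 3 of the 3 values shown sit. Compound 4 `Clc1ccc(-c2csc(N/N=C3\CCCC\C3=C/c3ccccc3)n2)cc1` differs from compound 1 by chloro in place of hydrogen on an aromatic carbon, in words chloro in place of hydrogen on an aromatic carbon. With every shown value at the limit, the expected step in this assay is a number no higher from compound 1 to compound 4 (the limit leaves the size open), none beyond the scatter. Compound 4 is therefore expected at 100000 nM, from 50000 nM to 200000 nM, most likely reported once more as a limit.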

Compound 4, half-maximal inhibitory concentration: > 100000 nM
Compound 4 was reported as a limit; the forecaster's own chance of this, stated with the estimate: 85%; the middle value sits exactly at the limit.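

No step can be read from compound 1 to compound 4, as both values are limits: the limit of > 100000 nM in this assay, at which 4 of the 4 values shown sit.

The compounds shown leave open what chloro in place of hydrogen on an aromatic carbon does in this assay and where any true value lies.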